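A few compounds are considered here, and "the series" means these few. Any claim that something is new, unique, unknown or untested is made for them only; others in the source may bear on it.

Working notes on the series. Among the measured compounds shown here, in an ADME assay on TZM cells (Homo sapiens) for cytotoxicity, read by XTT assay, with a stated time of 4 days (a lower number here means that less compound is tolerated, a higher number that more compound is tolerated), compound 2 `Cc1cc(/C=C/C#N)cc(C)c1Oc1cc(Nc2ccc(C#N)cc2)c(N)cc1C(=O)O` gives 14900 nM, the only plain number among the three values. The other two values are limits of the assay. Compound 1 `COC(=O)c1cc(N)c(Nc2ccc(C#N)cc2)cc1Oc1c(C)cc(/C=C/C#N)cc1C` reaches only the limit > 22800 nM in this assay. Compound 3 `CNC(=O)c1cc(N)c(Nc2ccc(C#N)cc2)cc1Oc1c(C)cc(CCC#N)cc1C` likewise reaches only the limit > 9100 nM in this assay. For the measured compounds named here, the single measured step, an at least 1.5-fold lower number from compound 1 to compound 2 (0.18 log units; that floor lies within the scatter), rests on the limit of > 22800 nM in this assay, at which 1 of the 3 values shown sits, and so has no firm size. Compound 4 `Cc1cc(/C=C/C#N)cc(C)c1Oc1cc(Nc2ccc(C#N)cc2)c(N)cc1S(N)(=O)=O` differs from compound 2 by sulfamoyl in place of carboxy on an aromatic carbon. Going by the values given here, no measured step covers this change, so no shift beyond the scatter is expected in this assay. Compound 4 is estimated at 18000 nM, between 7000 nM and 45000 nM. The expected step is a 1.2-fold higher number from compound 2 to compound 4 (0.08 log units; within the scatter), with a real chance that only a limit is returned.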

Compound 4, half-maximal cytotoxic concentration: > 21800 nM
Compound 4 ended at the assay's limit; the forecaster's own chance of this, stated with the estimate: 40%; middle value at least 1.2-fold (0.08 log units) away from the limit.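

In this assay, sulfamoyl in place of carboxy on an aromatic carbon gives an at least 1.4-fold higher number from compound 2 to compound 4 (0.16 log units; that floor lies within the scatter). This step has no firm size, because compound 4 reaches only a limit: the limit of > 21800 nM in this assay, at which 1 of the 4 values shown sits.

The step from compound 1 to compound 4 cannot be read, as both values are limits. A firm number for compound 4 is still needed to show whether this change moves beyond the scatter. Also open, going by these compounds, is how a primary carboxamide or a methylsulfonyl group on this aromatic carbon would read in this assay.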